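The source may report more compounds than this note shows. Statements on the series, on what has been measured and on what is new or still open speak of the compounds shown alone.

Measured so far:
Compound 1 `O=C(CCCCCCNC(=O)C(O)(O)C(F)(F)F)Nc1nc2ccccc2s1` gives 2860 nM in a functional assay on NCI-H522 cells (Homo sapiens) for inhibition, read by colorimetric assay, with a stated time of 3 days; a higher number here means a weaker inhibitor, a lower number a stronger inhibitor.
Compound 2 `O=C(CCCCCCNC(=O)C(O)(O)C(F)(F)F)Nc1ncc(-c2ccc(Br)cc2)s1` gives 2700 nM in this assay.

Compound 2 holds the lowest of the two numbers, but its gap to compound 1 lies within the scatter, so neither ranks above the other. Compound 3 `COc1ccc(-c2cnc(NC(=O)CCCCCCNC(=O)C(O)(O)C(F)(F)F)s2)cc1` awaits measurement in this assay. It differs from compound 2 by methoxy in place of bromo on an aromatic carbon. Within the data shown here, no step between measured compounds is on hand, so this change cannot be weighed against any measured pair. The change is expected to leave the number near that of compound 2, with the step of a 1.1-fold higher number from compound 2 to compound 3 (0.05 log units; within the scatter) expected to stay within the scatter. Compound 3 is therefore estimated at 3000 nM, range 1400 nM to 6500 nM.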

Compound 3, half-maximal inhibitory concentration: 3240 nM
Estimate against measurement, compound 3: 1.1-fold (0.03 log units) below; measured number inside the range.
By their numbers in this assay, from the lowest: compounds 2, 1 and 3 (each within the scatter of the next).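

In this assay, the 4-bromophenyl to 4-methoxyphenyl swap gives a 1.2-fold higher number from compound 2 to compound 3 (0.08 log units; within the scatter), so the two numbers cannot be told apart. At this place on the aromatic ring, bromo and methoxy thus read alike, although methoxy brings a hydrogen-bond acceptor and bromo does not. Nothing on hand offers an explanation for this result.

On these data alone, it remains open whether an amine or a carboxylic acid at this place would separate from compound 2 and compound 3. Also open, as far as these compounds go, is whether a longer chain would move the number.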